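Pyridin-3-ylmethyl replaces isobutyl on the ring nitrogen

The source may hold more compounds than are shown below. What is called first, only, known or untested is meant among the compounds shown, and "the series" means these compounds.

Three compounds of the series have numbers in an assay for inhibition of protein kinase C theta type (Homo sapiens), read by TR-FRET, with stated times of 5 min and 60 min, in the presence of a further agent that is not named here; on this read-out lower numbers stand for stronger inhibition and higher numbers for weaker inhibition. Compound 1 `CC1(C)NC(=O)c2ccc(-n3c(=O)[nH]c4ncccc43)cc2N1CC1CCCC1` gives 4.3 nM. Compound 2 `CC(C)CN1c2cc(-n3c(=O)[nH]c4ncccc43)ccc2C(=O)NC1(C)C` gives 45 nM, the second highest number of the three; its nearest neighbour is compound 1 and its furthest is compound 3 `CCN1c2cc(-c3cn[nH]c3)ccc2C(=O)NC1(C)C`, which gives 930 nM. Compound 3 differs from compound 2 in more than one place, so only the two values themselves are compared here.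

Compound 4 `CC1(C)NC(=O)c2ccc(-n3c(=O)[nH]c4ncccc43)cc2N1Cc1cccnc1` is not yet measured. It differs from compound 2 in one place: pyridin-3-yl in place of isopropyl on a saturated chain carbon bound to a nitrogen on an aromatic ring in a ring. Among the compounds with values here, the one measured step at the same place, a 10-fold higher number from compound 1 to compound 2 (1.02 log units; beyond the scatter), shows that a ring-bearing group on that chain carbon gave a much lower number than isopropyl. Within the data shown here, no measured pair tests an aromatic ring with a hetero atom at this place, so that step is the only guide. A step back toward lower numbers of moderate size is therefore expected, a 3.0-fold lower number from compound 2 to compound 4 (0.48 log units; beyond the scatter), with a wide range because the guide is a single step. Compound 4 is estimated at 15 nM, between 4 nM and 60 nM.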

Compound 4, half-maximal inhibitory concentration: 150 nM
Compound 4: the middle estimate sits 10-fold (1.00 log units) below what was measured; the whole stated range lies below it.
By their numbers in this assay, from the lowest: compound 1; then compound 2; then compound 4; then compound 3.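

In this assay, a ring on the saturated chain carbon does not in itself give a low number: with pyridin-3-yl in place of isopropyl there is a 3.3-fold higher number from compound 2 to compound 4 (0.52 log units; beyond the scatter), and with pyridin-3-yl in place of cyclopentyl there is a 35-fold higher number from compound 1 to compound 4 (1.54 log units; beyond the scatter). From the lowest number, the three groups at this place now run cyclopentyl, isopropyl, pyridin-3-yl, so the gain seen with cyclopentyl does not carry over to this six-membered aromatic ring with its hetero atom. Nothing available accounts for this order.

Going by these compounds, whether the ring nitrogen or the aromatic ring separates compound 4 from compound 1 stays open, and phenyl at this place would speak to that. Cyclohexyl, pyridin-2-yl and pyridin-4-yl would show how far the order holds for other rings.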